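Small chains versus cyclohexyl on the amine of the core

The source may hold more compounds than are shown below. What is called first, only, known or untested is meant among the compounds shown, and "the series" means these compounds.

Measured compounds:
Compound 1, `CNc1nc(-c2ccccc2)nc2c1nnn2Cc1ccccc1F`: 25 nM
Compound 2, `CCNc1nc(-c2ccccc2)nc2c1nnn2Cc1ccccc1F`: 11 nM
Compound 3, `Fc1ccccc1Cn1nnc2c(NC3CCCCC3)nc(-c3ccccc3)nc21`: 1.15 nM

In an assay on Cerebral cortex for displacement of a labelled ligand from adenosine receptor A1 (Bos taurus) (a lower number here means a stronger inhibitor, a higher number a weaker inhibitor), compound 3 gives 1.15 nM, the lowest number of the three and thus the strongest inhibitor here; the nearest is compound 2 and the furthest is compound 1, both beyond the scatter. Compound 4, `CC(O)CNc1nc(-c2ccccc2)nc2c1nnn2Cc1ccccc1F`, has not been measured. It differs from compound 3 in one place: 2-hydroxypropyl in place of cyclohexyl on a nitrogen on an aromatic ring.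

The measured steps bear on this directly. Going from a small chain to cyclohexyl on the same nitrogen lowered the number: a 22-fold lower number from compound 1 to compound 3 (1.34 log units; beyond the scatter) and a 9.6-fold lower number from compound 2 to compound 3 (0.98 log units; beyond the scatter). Between the two small chains the effect was smaller: a 2.3-fold lower number from compound 1 to compound 2 (0.36 log units; beyond the scatter). Compound 4 goes the other way, back from cyclohexyl to a short chain, so the expectation is a step in this assay of roughly the size seen in those two comparisons, but upward, landing near the range of compounds 1 and 2. Whether the hydroxyl on the chain shifts the number further cannot be judged from these three compounds alone.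

The estimated step is a 17-fold higher number from compound 3 to compound 4 (1.24 log units; beyond the scatter). Compound 4 is therefore expected to give about 20 nM, with a likely range from 6 nM to 70 nM.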

Compound 4, inhibition constant: 4.8 nM
For compound 4 the middle estimate is 4.2-fold (0.62 log units) above the measured one; measured number below the stated range.
By their numbers in this assay, from the lowest: compound 3; then compound 4; then compound 2; then compound 1.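

In this assay, cyclohexyl on this nitrogen still gives the lowest number, yet giving up the ring for 2-hydroxypropyl costs much less than giving it up for either small chain, with a 4.2-fold higher number from compound 3 to compound 4 (0.62 log units; beyond the scatter). The same chain also beats both small chains, with a 2.3-fold lower number from compound 2 to compound 4 (0.36 log units; beyond the scatter) and a 5.2-fold lower number from compound 1 to compound 4 (0.72 log units; beyond the scatter), so adding 1-hydroxyethyl to the chain carbon bound to the nitrogen lowers the number whether it replaces methyl or hydrogen. Among the three open chains in compound 1, compound 2 and compound 4, the number falls as the chain grows, and a chain with no ring comes closer to cyclohexyl than the two small chains suggested.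

Nothing available here explains why the chain carrying a hydroxyl gives a lower number than the ethyl chain. From the compounds shown here alone, what the hydroxyl itself contributes also stays open: separating it from the effect of chain length would take a plain propyl chain on the same nitrogen, along with an amine or a methoxy group in the hydroxyl's place.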